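Methyl on the Chain Carbon: Extending a Pair to a Fluoro Core

This account rests on a few compounds, and the source may have more. Where it says the series, first, only, none or still open, it means among the compounds named here.

Three analogues built on one shared core have been measured. Compound 1 `CC/C=C\C(=O)Nc1cc(Nc2ncc(C#N)c(-c3cn(C)c4ccccc34)n2)c(OC)cc1N(C)CCN(C)C` gives, in a functional assay on HepG2 cells (Homo sapiens) for antiproliferative activity, read by MTT assay, with a stated time of 72 h (on this read-out higher numbers stand for weaker inhibition and lower numbers for stronger inhibition), a half-maximal inhibitory concentration of 1360 nM. Compound 2 `COc1cc(N(C)CCN(C)C)c(NC(=O)/C=C\C(C)C)cc1Nc1ncc(C#N)c(-c2cn(C)c3ccccc23)n1` differs from compound 1 by methyl in place of hydrogen on a saturated chain carbon bound to a double-bonded chain carbon and a saturated chain carbon; in this assay compound 2 gives 1810 nM, and the step is a 1.3-fold higher number from compound 1 to compound 2 (0.12 log units; within the scatter). Compound 3 `CC/C=C\C(=O)Nc1cc(Nc2ncc(C#N)c(-c3cn(C)c4ccc(F)cc34)n2)c(OC)cc1N(C)CCN(C)C` differs from compound 1 by fluoro in place of hydrogen on an aromatic carbon; in this assay compound 3 gives 5880 nM, and the step is a 4.3-fold higher number from compound 1 to compound 3 (0.64 log units; beyond the scatter). Compound 3 thus stands at the highest number of the three, beyond the scatter from both others, while compound 1 and compound 2 lie within the scatter of each other, so no order between those two is claimed.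

Compound 4 `COc1cc(N(C)CCN(C)C)c(NC(=O)/C=C\C(C)C)cc1Nc1ncc(C#N)c(-c2cn(C)c3ccc(F)cc23)n1` has not been measured. It differs from compound 3 by methyl in place of hydrogen on a saturated chain carbon bound to a double-bonded chain carbon and a saturated chain carbon. The place line of this change reads word for word as the place line of the change from compound 1 to compound 2, so it is the same change, now carried out on the core that differs from the core of compound 1 by fluoro in place of hydrogen on an aromatic carbon. Within the data shown here, the only precedent for the change is the one pair, and it lay within the scatter.

Compound 4 is therefore expected to sit close to compound 3, with an estimated step of a 1.3-fold higher number from compound 3 to compound 4 (0.11 log units; within the scatter), because the earlier step of a 1.3-fold higher number from compound 1 to compound 2 (0.12 log units; within the scatter) was small. The estimate for compound 4 in this assay is 7600 nM, with a range from 3500 nM to 16000 nM.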

Compound 4, half-maximal inhibitory concentration: 2840 nM
Compound 4: the middle estimate sits 2.7-fold (0.43 log units) above what was measured, outside the stated range (below it).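

On the fluoro core the methyl step reads a 2.1-fold lower number from compound 3 to compound 4 (0.32 log units; beyond the scatter), whereas on the core of compound 1 the same change stayed within the scatter, so in this assay the change does not carry from one core to the other with a single size or even a single direction: the same change on two cores in this assay, a 1.3-fold higher number (0.12 log units; within the scatter) from compound 1 to compound 2 and a 2.1-fold lower number (0.32 log units; beyond the scatter) from compound 3 to compound 4, 2.8-fold (0.44 log units) apart, beyond the scatter of two such steps. Read the other way round, the fluoro change gives a 1.6-fold higher number from compound 2 to compound 4 (0.20 log units; within the scatter), a much smaller step than it gave without the added methyl, so in these compounds the two changes do not simply add up: the same change on two cores in this assay, a 4.3-fold higher number (0.64 log units; beyond the scatter) from compound 1 to compound 3 and a 1.6-fold higher number (0.20 log units; within the scatter) from compound 2 to compound 4, 2.8-fold (0.44 log units) apart, beyond the scatter of two such steps. This shows that the effect of either change here depends on the other, but it rests on one set of four compounds in a single assay, and it does not show why the two changes interact or whether the same holds for the rest of the series.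

The compounds shown leave open whether a longer chain or a cyclopropyl group at the same place on the chain would depend on the core in the same way. They also leave open whether chloro or methoxy in place of fluoro on that aromatic carbon would alter the methyl step as fluoro does.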